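The source may hold more compounds than are shown below. What is called first, only, known or untested is meant among the compounds shown, and "the series" means these compounds.

The two measured compounds share one core. Compound 1 `Cc1ccc(Nc2cc(NC(=O)Nc3c(Cl)cccc3Cl)ncn2)cc1F` gives 45.3% in a functional assay on NCI-H1581 cells (Homo sapiens) for inhibition, read by MTT assay, with a stated time of 48 h, tested at 10 uM (on this read-out lower numbers stand for less inhibition and higher numbers for more inhibition at the one concentration tested (going by the name of the read-out)), the higher of the two numbers shown. Compound 2 `COc1cc(NC(=O)Nc2cc(Nc3ccc(C)c(C)c3)ncn2)cc(OC)c1` gives 20.1% in this assay, a result that lies beyond the scatter below that of compound 1. Compound 3 `COc1ccc(Nc2cc(NC(=O)Nc3c(Cl)cccc3Cl)ncn2)cc1C` has not yet been measured; it differs from compound 1 in one place, (4-methoxy-3-methylphenyl in place of 3-fluoro-4-methylphenyl on a nitrogen on an aromatic ring). Within the data shown here, no step between measured compounds isolates this exchange, so the expectation rests on compound 1 alone. The expected modest downward step is estimated as a number 10.3 percentage points lower from compound 1 to compound 3 (beyond the scatter). Compound 3 is estimated at 35%, somewhere between 15% and 55%.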

Compound 3, a percentage reported as inhibition, at one concentration (the size of the read-out at that concentration, not a potency): 45.1%
Compound 3: the middle estimate sits 10.1 percentage points below what was measured; measured number inside the range.
By their numbers in this assay, from the lowest: compound 2; then compounds 3 and 1 (each within the scatter of the next).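

In this assay, 4-methoxy-3-methylphenyl in place of 3-fluoro-4-methylphenyl on a nitrogen on an aromatic ring gives a number 0.2 percentage points lower from compound 1 to compound 3 (within the scatter), so this exchange leaves the read-out unchanged within the scatter. The entering group counts one hydrogen-bond acceptor and the leaving group none, yet the two compounds cannot be told apart here. No measurement at hand explains this result. On these data alone, whether the same holds for an amine or a carboxylic acid at this position, or for a longer chain in place of methoxy, remains open.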